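The source may hold more compounds than are shown below. What is called first, only, known or untested is meant among the compounds shown, and "the series" means these compounds.

Measured compounds:
compound 1 `N/C(=N\NC(=S)N1CCCCCC1)c1ccccn1`: 740 nM
compound 2 `N/C(=N\NC(=S)N1CCOCC1)c1ccccn1`: 680 nM
compound 3 `N/C(=N\NC(=S)N1CCOCC1)c1ccc(F)cn1`: 1500 nM

All three were tested in a functional assay on A-375 cells (Homo sapiens) for cytotoxicity, read by MTT assay, with a stated time of 72 h; a higher number here means a weaker inhibitor, a lower number a stronger inhibitor. Compound 1 and compound 2 give numbers within the scatter of each other; how their two cores differ is not broken down here. Compound 3 is obtained from compound 2 by fluoro in place of hydrogen on an aromatic carbon, and that step is a 2.2-fold higher number from compound 2 to compound 3 (0.34 log units; beyond the scatter). Compound 4 `N/C(=N\NC(=S)N1CCCCCC1)c1ccc(F)cn1` has not yet been measured; it is obtained from compound 1 by fluoro in place of hydrogen on an aromatic carbon, the same change at the same place. For the measured compounds named here, only one earlier instance of this change is available, so the expectation rests on that single step. For compound 4 the expected step is a 2.2-fold higher number from compound 1 to compound 4 (0.33 log units; beyond the scatter), because the matching change gave a 2.2-fold higher number from compound 2 to compound 3 (0.34 log units; beyond the scatter). Compound 4 is estimated at 1600 nM, with a likely range from 800 nM to 3300 nM.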

Compound 4, half-maximal inhibitory concentration: 960 nM
For compound 4 the middle estimate is 1.7-fold (0.22 log units) above the measured one; the measured number falls inside the stated range.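

In this assay, fluoro in place of hydrogen on an aromatic carbon gives a 1.3-fold higher number from compound 1 to compound 4 (0.11 log units; within the scatter), so on this core the step does not stand clear of the scatter. Set beside the earlier step, the two cores do not separate: the same change on two cores in this assay, a 2.2-fold higher number (0.34 log units; beyond the scatter) from compound 2 to compound 3 and a 1.3-fold higher number (0.11 log units; within the scatter) from compound 1 to compound 4, 1.7-fold (0.23 log units) apart, within the scatter of two such steps. The two steps fit a single effect of the change across these cores, but two pairs do not fix its size and do not show that it carries to any other core.

Open, going by these compounds, is whether chloro, methoxy or an amine on the same aromatic carbon would follow the fluoro step. Also open, on these data alone, is whether the step holds on a core carrying a dimethylamino group.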